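One Carbonyl Change Applied Across Two Urea Cores

The source may report more compounds than this note shows. Statements on the series, on what has been measured and on what is new or still open speak of the compounds shown alone.

Of the compounds shown here, three have been measured in an ADME assay on the whole organism with Oryza sativa as the target, tested at 1 uM; a lower number here means a stronger effect, a higher number a weaker effect of the compound at the concentration tested. Compound 1 `CCOC(=O)c1cccc(NC(=O)N[C@H](C)c2ccccc2)c1` gives 94% in this assay. Compound 2 `CCOC(=O)c1ccc(NC(=O)N[C@H](C)c2ccccc2)cc1` gives 100%, the highest of the three numbers, though its nearest neighbour is compound 1, whose number lies within the scatter of it; its furthest is compound 3, whose number lies beyond the scatter. Compound 3 `CC(=O)c1cccc(NC(=O)N[C@H](C)c2ccccc2)c1` gives 88%.

Compound 1 and compound 2 are built from the same atoms joined differently; the difference between the two cores is not broken down here. Compound 1 and compound 3 share a core and differ by methyl in place of ethoxy on a carbonyl carbon, a change that gave a number 6 percentage points lower from compound 1 to compound 3 (within the scatter).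

Compound 4 `CC(=O)c1ccc(NC(=O)N[C@H](C)c2ccccc2)cc1` has not yet been measured in this assay. It differs from compound 2 by methyl in place of ethoxy on a carbonyl carbon. The place of this change reads word for word as it does between compound 1 and compound 3, so it is the same change, occurring twice among the four compounds, once on each core.

On the core of compound 1 the change stayed within the scatter, and compound 2 already sits at the top of the measured range. The step is therefore expected to be a number 6 percentage points lower from compound 2 to compound 4 (within the scatter), because the same change gave a number 6 percentage points lower from compound 1 to compound 3 (within the scatter). Compound 4 is expected to give 94%, with a likely range from 82% to 102%.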

Compound 4, a percentage reported as activity, at one concentration (the size of the read-out at that concentration, not a potency): 93%
The estimate for compound 4 lay 1 percentage points above the measured number, and the stated range covers the measured number.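

In this assay, the change from ethoxycarbonyl to acetyl gave a number 7 percentage points lower from compound 2 to compound 4 (within the scatter), and set beside the earlier step it reads much the same on both cores: the same change on two cores in this assay, a number 6 percentage points lower (within the scatter) from compound 1 to compound 3 and a number 7 percentage points lower (within the scatter) from compound 2 to compound 4, 1 percentage points apart, within the scatter of two such steps. Within this series, then, the change carried from one core to the other without any detectable difference in its step. This does not show that the change itself has a real effect, since each step taken alone stays within the scatter, so the agreement is between two small steps, and it says nothing about whether a step beyond the scatter would carry over in the same way, nor about any core other than these two.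

The compounds shown leave open what a carboxylic acid, a primary amide or a longer chain such as butoxy would do in place of ethoxy or methyl on the carbonyl carbon, and whether such a replacement would give the same step on both cores. All four compounds also keep the rest of the structure unchanged, so the effect of an amine or a halogen elsewhere on the molecule remains an open question too.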